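This account rests on a few compounds, and the source may have more. Where it says the series, first, only, none or still open, it means among the compounds named here.

Compound 1 `O=C1C=C(NC2CCCCC2)C(=O)c2c1nc1n2[C@H]2OC[C@@H](O)[C@H]2OC1` was tested in a functional assay on ECa-109 cells for inhibition, with ECa-109 cell line (Homo sapiens) as the target, read by sulforhodamine B assay; on this read-out higher numbers stand for weaker inhibition and lower numbers for stronger inhibition. In that assay compound 1 gives only a limit, > 16000 nM. Compound 2 `CCCN(CCC)C1=CC(=O)c2nc3n(c2C1=O)[C@H]1OC[C@@H](O)[C@H]1OC3` carries the change described as dipropylamino in place of cyclohexylamino on a double-bonded ring carbon. In this assay compound 2 also gives only a limit, > 16000 nM. The step that the two limits leave unreadable from compound 1 to compound 2 therefore cannot be read, since both ends sit at the limit of > 16000 nM in this assay, at which 3 of the 3 values shown sit. Compound 3 `O=C1C(NC2CCCCC2)=CC(=O)c2c1nc1n2[C@H]2OC[C@@H](O)[C@H]2OC1` is built on a core that differs from the core of compound 1; the difference between the two cores is not broken down here. In this assay compound 3 likewise gives only a limit, > 16000 nM.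

Compound 4 `CCCN(CCC)C1=CC(=O)c2c(nc3n2[C@H]2OC[C@@H](O)[C@H]2OC3)C1=O` has not yet been measured. It differs from compound 3 by dipropylamino in place of cyclohexylamino on a double-bonded ring carbon, the same change, at the same kind of place, that separates compound 1 from compound 2. Because all three measured values sit at the limit of > 16000 nM in this assay, at which 3 of the 3 values shown sit, the step from compound 3 to compound 4 is expected to be a step that the limit leaves unreadable from compound 3 to compound 4. On that footing compound 4 is estimated at 40000 nM, between 16000 nM and 120000 nM, most likely reported again only as a limit.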

Compound 4, half-maximal inhibitory concentration: > 16000 nM
Compound 4 was reported as a limit (the forecaster's own chance of this, stated with the estimate: 85%); the middle value is on the limit's open side.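

The step between compound 3 and compound 4 cannot be read, because both compounds give only a limit, the same one: the limit of > 16000 nM in this assay, at which 4 of the 4 values shown sit. The compounds shown leave open whether dipropylamino in place of cyclohexylamino changes inhibition at all on either core, and where the true value of any of the four compounds lies.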